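Stereocentre definition in a hydrazone acid series

This account rests on a few compounds, and the source may have more. Where it says the series, first, only, none or still open, it means among the compounds named here.

Measured so far:
compound 1 `C[C@@H]1CC/C(=N\Nc2ccc(O)cc2)c2ncc(C(=O)O)c(=O)n21` — > 100 umol/kg
compound 2 `CCOc1ccc(N/N=C2\CCC(C)n3c2ncc(C(=O)O)c3=O)cc1` — > 100 umol/kg

In a functional assay on the whole organism for inhibition, with Rattus norvegicus as the target (on this read-out lower numbers stand for an effect already at smaller amounts and higher numbers for an effect only at larger amounts of compound), compound 1 `C[C@@H]1CC/C(=N\Nc2ccc(O)cc2)c2ncc(C(=O)O)c(=O)n21` gives only a limit, > 100 umol/kg. In this assay compound 2 `CCOc1ccc(N/N=C2\CCC(C)n3c2ncc(C(=O)O)c3=O)cc1` likewise gives only a limit, > 100 umol/kg. Both shown values sit at the limit of > 100 umol/kg in this assay, at which 2 of the 2 values shown sit, so compound 2 stands at the limit with nothing to rank it against. Compound 3 `CCOc1ccc(N/N=C2\CC[C@@H](C)n3c2ncc(C(=O)O)c3=O)cc1` differs from compound 2 only as counted in the two compounds have the same atoms and bonds; at least one stereo element is drawn with a configuration in one of them and without one in the other: 1 of 2 stereo elements differ; a stereocentre at a saturated ring carbon is drawn without a configuration in compound 2 and R in compound 3. Going by the values given here, no step between measured compounds is available. Nothing beyond the scatter is expected for a step that the limit leaves unreadable from compound 2 to compound 3. Compound 3 is expected to give 200 umol/kg, between 100 umol/kg and 1000 umol/kg, most likely again as a limit.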

Compound 3, dose for 50% inhibition: > 100 umol/kg
Compound 3 gave a limit, no number; the forecaster's own chance of this, stated with the estimate: 85%; the middle value is on the limit's open side.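

Compound 2 and compound 3 both stay at a limit in this assay, as does compound 1, so no step among the three can be read: the limit of > 100 umol/kg in this assay, at which 3 of the 3 values shown sit.

The compounds shown leave open what dose any of them would need and whether the defined stereocentre of compound 3 changes the effect relative to compound 2.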